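The source may hold more compounds than are shown below. What is called first, only, known or untested is meant among the compounds shown, and "the series" means these compounds.

Measured compounds in a functional assay on HCT-116 cells (Homo sapiens) for cytotoxicity, with a stated time of 48 h; on this read-out lower numbers stand for stronger inhibition and higher numbers for weaker inhibition:
compound 1 `O=[N+]([O-])c1ccc(CN2CCC(n3cc(CC(OCc4cc(-c5ccccc5)no4)c4ccc(Br)cc4)nn3)CC2)cc1`: > 25000 nM, a limit of the assay
compound 2 `O=[N+]([O-])c1ccc(CN2CCC(n3cc(CC(OCc4cc(-c5ccc(F)cc5)no4)c4ccc(Br)cc4)nn3)CC2)cc1`: > 25000 nM, a limit of the assay
compound 3 `COc1cccc(-c2cc(COC(Cc3cn(C4CCN(Cc5ccc([N+](=O)[O-])cc5)CC4)nn3)c3ccc(Br)cc3)on2)c1`: > 25000 nM, a limit of the assay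

Compound 3 stands at the same place as everything measured so far in this assay: at the limit described in the limit of > 25000 nM in this assay, at which 3 of the 3 values shown sit, with no number behind it. The steps a step that the two limits leave unreadable from compound 1 to compound 2, a step that the two limits leave unreadable from compound 1 to compound 3 and a step that the two limits leave unreadable from compound 2 to compound 3 are therefore all unreadable in size; each of them is a change on the same aromatic ring that compound 4 varies, and none of them moved any compound off the limit.

Compound 4 `N#Cc1cccc(-c2cc(COC(Cc3cn(C4CCN(Cc5ccc([N+](=O)[O-])cc5)CC4)nn3)c3ccc(Br)cc3)on2)c1` differs from compound 3 by cyano in place of methoxy on an aromatic carbon. For the measured compounds named here, the three unreadable steps are the only evidence that bears on this change, and they give no direction and no size, only the repeated finding that substitution on this ring left the read-out at the limit.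

The expectation for compound 4 in this assay is accordingly a further limit rather than a number: an estimate of 30000 nM, with a range from 10000 nM to 100000 nM. The step from compound 3 that this estimate implies, a step that the limit leaves unreadable from compound 3 to compound 4, is expected to stay within the scatter.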

Compound 4, half-maximal inhibitory concentration: > 25000 nM
Compound 4 was reported as a limit (the forecaster's own chance of this, stated with the estimate: 85%); the middle value is on the limit's open side.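

In this assay compound 4 gives > 25000 nM as a limit of the assay, so its steps from compound 1, compound 2 and compound 3 cannot be read in size. All four compounds stand at the same place: the limit of > 25000 nM in this assay, at which 4 of the 4 values shown sit. The compounds shown leave open whether any change to this aromatic ring gives a measurable value.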